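Defined Stereochemistry and Metabolic Stability of Compound 4

The source may hold more compounds than are shown below. What is called first, only, known or untested is meant among the compounds shown, and "the series" means these compounds.

Compound 1, `CS(=O)(=O)Nc1ccc2c(c1)S(=O)(=O)N=C(C1=C(O)C3CCCC3N(Cc3ccc(F)cn3)C1=O)N2`, in an in vitro ADME assay on microsomes from liver (Homo sapiens) for metabolic stability (a lower number here means that the compound disappears faster, a higher number that the compound lasts longer), gives > 1 h, which is a limit of the assay. Compound 2, `CC(C)(C)CCN1C(=O)C(C2=NS(=O)(=O)c3cc(NS(C)(=O)=O)ccc3N2)=C(O)C2CCCCC21`, gives 0.267 h. Compound 3, `CS(=O)(=O)Nc1ccc2c(c1)S(=O)(=O)N=C(C1=C(O)C3CCCCC3N(Cc3ccc(F)cc3)C1=O)N2`, gives > 1 h, again a limit of the assay.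

Compound 3 thus stands not at a number but at a limit, and it shares this with one other compound; this is the situation described by the limit of > 1 h in this assay, at which 2 of the 3 values shown sit. Among the measured steps only one exists: an at least 3.7-fold higher number from compound 2 to compound 3 (0.57 log units; beyond the scatter). That step exchanges a group on the ring nitrogen and says nothing about stereochemistry.

Compound 4, `CS(=O)(=O)Nc1ccc2c(c1)S(=O)(=O)N=C(C1=C(O)[C@H]3CCCC[C@H]3N(Cc3ccc(F)cc3)C1=O)N2`, differs from compound 3 in this way: the two compounds have the same atoms and bonds; at least one stereo element is drawn with a configuration in one of them and without one in the other: 2 of 2 stereo elements differ; a stereocentre at a saturated ring carbon is drawn without a configuration in compound 3 and S in compound 4; a stereocentre at a saturated ring carbon is drawn without a configuration in compound 3 and R in compound 4. The atoms and bonds are the same; compound 4 is one defined stereoisomer of the material of compound 3. Among the compounds with values here, no measured step shows what fixing these two centres does in this assay, and the starting point is a limit, not a number.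

The expectation is therefore no step beyond the scatter, so that a step that the limit leaves unreadable from compound 3 to compound 4 is estimated as essentially flat. Compound 4 is expected to give 1.5 h, with a range from 0.6 h to 4 h, and most likely the assay again reports only a limit.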

Compound 4, half-life: > 1 h
Compound 4: only a limit was reported; the forecaster's own chance of this, stated with the estimate: 75%; the middle value does not contradict the limit.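

In this assay compound 4 gives > 1 h, which is a limit of the assay. Compound 3 also stands at a limit, so no step from compound 3 to compound 4 can be read: the limit of > 1 h in this assay, at which 3 of the 4 values shown sit.

The compounds shown leave open how long compound 3 and compound 4 actually last, and whether the defined configuration of compound 4 makes any difference.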